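Swapping Naphthalen-1-yl for Phenyl on a Ring Nitrogen

The compounds below may be only part of what the source reports. "The series", "measured", "known", "first", "only" and "open" are said of these compounds alone.

Compound 1, `COc1cccc([C@H]2CC[C@@H](NCCOc3ccccn3)CC2)c1`: in an assay on cell membranes for displacement of a labelled ligand from Adrenergic receptor alpha-1 (Rattus norvegicus) (on this read-out lower numbers stand for stronger inhibition and higher numbers for weaker inhibition), compound 1 gives > 850 nM, which is a limit of the assay, not a number.
Compound 2, `COc1cccc([C@H]2CC[C@@H](N3CCN(c4cccc5ccccc45)CC3)CC2)c1`: in this assay compound 2 gives 5540 nM.

Going by the values given here, compound 2 holds the only numerical value shown; the other entry is a limit, as the limit of > 850 nM in this assay, at which 1 of the 2 values shown sits, records. Compound 3, `COc1cccc([C@H]2CC[C@@H](N3CCN(c4ccccc4)CC3)CC2)c1`, differs from compound 2 by phenyl in place of naphthalen-1-yl on an amine nitrogen in a ring. Among the compounds with values here, no measured pair isolates this change, so the expectation for compound 3 is a step of a 1.4-fold higher number from compound 2 to compound 3 (0.16 log units; within the scatter) that stays near the scatter. Compound 3 is therefore estimated at 8000 nM, within 2000 nM to 30000 nM.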

Compound 3, inhibition constant: 2250 nM
Beside the measured number, compound 3's estimate is 3.6-fold (0.55 log units) above it, within the range that was stated.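

On the amine nitrogen in the ring, phenyl gives stronger inhibition than naphthalen-1-yl: in this assay the swap gives a 2.5-fold lower number from compound 2 to compound 3 (0.39 log units; beyond the scatter). Going by these compounds alone, this is the first sign that the number responds to the group at this position, though the step is modest. Nothing shown explains why phenyl does better here. Still open, going by these compounds, is whether a chlorine atom on the phenyl, or a benzyl group in its place, would move the number further, and in which direction.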